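Replacing a Trimethoxyphenyl Group: What One Step Suggests

The compounds below may be only part of what the source reports. "The series", "measured", "known", "first", "only" and "open" are said of these compounds alone.

In a functional assay on A549 cells (Homo sapiens) for cytotoxicity, read by MTT assay, with a stated time of 48 h (a lower number here means a stronger inhibitor, a higher number a weaker inhibitor), compound 1 `COc1ccc(OC)c(C2=NOC(COc3ccc(-c4nnnn4-c4cc(OC)c(OC)c(OC)c4)cc3N)C2)c1` gives 1930 nM and compound 2 `COc1cc(C2=NOC(COc3ccc(-c4nnnn4-c4cc(OC)c(OC)c(OC)c4)cc3N)C2)cc(OC)c1OC` gives 2060 nM as its half-maximal inhibitory concentration. Within the data shown here, these two numbers lie within the usual scatter of repeated measurements, so compound 2 stands level with compound 1, the only other compound measured so far.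

Compound 3 `COc1cc(C2=NOC(COc3ccc(-c4nnnn4-c4cc(OC)c(OC)c(OC)c4)cc3N)C2)ccc1O` differs from compound 2 in one place, on a carbon with a double bond to nitrogen of a five-membered non-aromatic ring, where 4-hydroxy-3-methoxyphenyl stands in place of 3,4,5-trimethoxyphenyl (4-hydroxy-3-methoxyphenyl in place of 3,4,5-trimethoxyphenyl on a carbon with a double bond to nitrogen). Among the measured compounds shown here, one measured step bears on this: the exchange at the same place (a 1.1-fold higher number from compound 1 to compound 2 (0.03 log units; within the scatter)) stayed within the scatter. For the measured compounds named here, that is only a single step, however, and compound 3 carries a hydroxy group that neither measured compound has at this place. Nothing beyond the scatter is therefore expected in this assay, and the estimated move (a 1.2-fold lower number from compound 2 to compound 3 (0.08 log units; within the scatter)) has no firm direction. For compound 3 the estimated value is 1700 nM (range 600 nM to 5000 nM).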

Compound 3, half-maximal inhibitory concentration: 2010 nM
The estimate for compound 3 lay 1.2-fold (0.07 log units) below the measured number; measured number inside the range.
By their numbers in this assay, from the lowest: compounds 1, 3 and 2 (each within the scatter of the next).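

The exchange at this place now includes a group with a hydroxy group, and the number still stays within the scatter in this assay (a 1.0-fold lower number from compound 2 to compound 3 (0.01 log units; within the scatter)). In that step, 4-hydroxy-3-methoxyphenyl, with 9 heavy atoms and 1 hydrogen-bond donor, replaces 3,4,5-trimethoxyphenyl, with 12 heavy atoms and 0 hydrogen-bond donors, so neither difference registers in this read-out. The comparison with 2,5-dimethoxyphenyl agrees (a 1.0-fold higher number from compound 1 to compound 3 (0.02 log units; within the scatter)), which means that these three substituted phenyl groups on the carbon with a double bond to nitrogen cannot be told apart here, though nothing available explains why.

On these data alone, all three compounds still carry a phenyl group with methoxy substituents at this place, so it remains open whether this level would hold with a very different group there, such as a cyclohexyl ring, or with a phenyl group bearing an amine or a carboxylic acid. The shared core is also the same throughout, so these results cannot show whether a change elsewhere in the molecule would move the number beyond the scatter.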